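Coumarin-side-chain series: formyl to acetylethenyl step

The compounds below may be only part of what the source reports. "The series", "measured", "known", "first", "only" and "open" are said of these compounds alone.

Compound 1 `COc1cc(OC)c2ccc(=O)oc2c1CC(C)(C)C(=O)O` and compound 2 `COc1cc(OC)c2ccc(=O)oc2c1CC(C)(C)C=O` share one core and differ only at the end of the side chain. In a functional assay on RAW264.7 cells (Mus musculus), with a stated time of 24 h (on this read-out higher numbers stand for weaker inhibition and lower numbers for stronger inhibition), compound 1 gives 12400 nM, and compound 2 gives 12400 nM. Within the data shown here, the single measured step, no change at the digits printed from compound 1 to compound 2 (within the scatter), shows no change, so compound 2 stands level with compound 1 on these numbers.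

Compound 3 `COc1cc(OC)c2ccc(=O)oc2c1/C=C/C(C)=O` is the next entry. The change is 2-acetylethenyl in place of 2-formyl-2-methylpropyl on an aromatic carbon. Among the measured compounds shown here, no measured step touches this kind of change: the one step on record alters only the carbonyl end of the chain while the chain itself is kept, whereas here the chain is shortened and gains a double bond. That step therefore carries little weight for compound 3, and no step beyond the scatter is expected in this assay. The estimate for compound 3 is 9000 nM, within 2500 nM to 30000 nM, meaning an expected step of a 1.4-fold lower number from compound 2 to compound 3 (0.14 log units; within the scatter).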

Compound 3, half-maximal inhibitory concentration: 6000 nM
Beside the measured number, compound 3's estimate is 1.5-fold (0.18 log units) above it; the range from low to high includes it.
By their numbers in this assay, from the lowest: compound 3; then compounds 1 and 2 (each within the scatter of the next).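

In this assay, 2-acetylethenyl in place of 2-formyl-2-methylpropyl on this aromatic carbon gives a 2.1-fold lower number from compound 2 to compound 3 (0.32 log units; beyond the scatter) and 2-acetylethenyl in place of 2-carboxy-2-methylpropyl gives a 2.1-fold lower number from compound 1 to compound 3 (0.32 log units; beyond the scatter) as a modest move beyond the scatter. The earlier pair showed only that the carbonyl end of a retained chain could change with no change at the printed digits, whereas compound 3 shows that the read-out responds, though modestly, when the chain itself is replaced. Both steps replace the whole chain, so the added double bond and the other changes in the chain cannot be separated on these compounds. Still open, on these data alone, is whether a saturated 3-oxobutyl chain, a longer chain or an amine at the chain end would keep or extend this step, and no measured evidence here accounts for it.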